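The source may hold more compounds than are shown below. What is called first, only, known or untested is meant among the compounds shown, and "the series" means these compounds.

Compound 1, `CC(C)[C@H](NC(=O)COc1cccc2ccccc12)C(=O)N[C@@H](CC(=O)O)C(=O)CSC1=NCCS1`. In a functional assay on Jurkat cells (Homo sapiens) for inhibition (on this read-out higher numbers stand for weaker inhibition and lower numbers for stronger inhibition), compound 1 gives > 200000 nM, which is a limit of the assay and not a number.
Compound 2, `CC(C)[C@H](NC(=O)COc1cccc2ccccc12)C(=O)N[C@@H](CC(=O)O)C(=O)CSc1nnc(-c2ccccc2)o1`. In this assay compound 2 gives 150000 nM.
Compound 3, `CC(C)[C@H](NC(=O)COc1cccc2ccccc12)C(=O)N[C@@H](CC(=O)O)C(=O)CSc1nncn1C`. In this assay compound 3 gives > 200000 nM, again a limit of the assay.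

Compound 2 therefore holds the only number shown; the other two values sit at the limit of > 200000 nM in this assay, at which 2 of the 3 values shown sit. All three compounds share one core and differ only in the group carried on the sulfur. Compound 4, `CC(C)[C@H](NC(=O)COc1cccc2ccccc12)C(=O)N[C@@H](CC(=O)O)C(=O)COn1nnc2ccccc21`, goes one step further from compound 2: a group of 10 heavy atoms (6 carbon, 3 nitrogen, 1 oxygen; one five-membered aromatic ring with 3 hetero atoms, one six-membered aromatic ring of carbon only) in place of a group of 12 heavy atoms (8 carbon, 2 nitrogen, 1 oxygen, 1 sulfur; one five-membered aromatic ring with 3 hetero atoms, one six-membered aromatic ring of carbon only), on a saturated chain carbon bound to a carbonyl carbon. Among the compounds with values here, two measured steps bear on a change at this end of the molecule. One is an at least 1.3-fold lower number from compound 1 to compound 2 (0.12 log units; that floor lies within the scatter), the other at least 1.3-fold higher number from compound 2 to compound 3 (0.12 log units; that floor lies within the scatter); each is only a floor, and each floor lies within the scatter, so neither shows that swapping the group on the sulfur moves the number beyond the scatter. Within the data shown here, in compound 4 the sulfur itself leaves, which none of the measured steps covers. The expected step is therefore small, with no clear direction: no change at the digits printed from compound 2 to compound 4 (within the scatter). Compound 4 is estimated at 150000 nM in this assay, with a range from 60000 nM to 300000 nM, and a fair chance that only a limit is reported.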

Compound 4, half-maximal inhibitory concentration: > 200000 nM
Compound 4 gave a limit, no number (the forecaster's own chance of this, stated with the estimate: 45%); middle value at least 1.3-fold (0.12 log units) away from the limit.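

This is the first change shown in which the sulfur itself leaves: on the saturated chain carbon bound to a carbonyl carbon, (5-phenyl-1,3,4-oxadiazol-2-yl)sulfanyl gives way to a sulfur-free group with the same two ring types, and the result is an at least 1.3-fold higher number from compound 2 to compound 4 (0.12 log units; that floor lies within the scatter). So losing the sulfur, like swapping the group on it, shows no move beyond the scatter, although the true size of this step is hidden by the limit, and the steps from compound 1 and compound 3 to compound 4 cannot be read, since both values in each pair are limits. Compound 2 remains the only compound with a number in this assay, and the set now gathers at one edge of the read-out: the limit of > 200000 nM in this assay, at which 3 of the 4 values shown sit.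

Going by these compounds, how far compound 1, compound 3 and compound 4 lie past that limit stays open, so these groups cannot be ranked against one another. Also open, on these data alone, is whether a simple amine or a phenoxy group on the same carbon would give a number clearly lower than that of compound 2.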